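Working notes on a set of triaryl analogues

A few compounds are considered here, and "the series" means these few. Any claim that something is new, unique, unknown or untested is made for them only; others in the source may bear on it.

Measured so far:
compound 1, `Cc1ccsc1-c1cc(-c2ccoc2)cc(-c2ccc(Cl)cc2)n1`, gives 20100 nM in a functional assay on DU-145 cells (Homo sapiens) for cytotoxicity, read by ELISA, with a stated time of 4 days; a lower number here means a stronger inhibitor, a higher number a weaker inhibitor
compound 2, `Clc1ccc(-c2cc(-c3ccoc3)cc(-c3ccc(Cl)s3)n2)cc1`, gives 29500 nM in this assay
compound 3, `Cc1ccsc1-c1cc(-c2ccc(Cl)o2)cc(-c2ccco2)n1`, gives 27300 nM in this assay

From compound 1 to compound 2 the change is 5-chlorothiophen-2-yl in place of 3-methylthiophen-2-yl on an aromatic carbon, and it made a 1.5-fold higher number from compound 1 to compound 2 (0.17 log units; within the scatter).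

Compound 4, `Clc1ccc(-c2cc(-c3ccco3)nc(-c3ccc(Cl)s3)c2)o1`, is not yet measured. It differs from compound 3 by 5-chlorothiophen-2-yl in place of 3-methylthiophen-2-yl on an aromatic carbon. The difference between the core of compound 1 and the core of compound 3 is not broken down here. The surroundings of the place are not identical: in compound 1 the exchanged group is meta to a 4-chlorophenyl group and meta to a furan-3-yl group, in compound 3 meta to a 5-chlorofuran-2-yl group and meta to a furan-2-yl group, so this is the same kind of change, not the same change.

For compound 4 a step of a 1.4-fold higher number from compound 3 to compound 4 (0.14 log units; within the scatter) is expected, resting on the earlier pair because a 1.5-fold higher number from compound 1 to compound 2 (0.17 log units; within the scatter) lies within the scatter. Compound 4 is estimated at 38000 nM, expected between 15000 nM and 90000 nM.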

Compound 4, half-maximal inhibitory concentration: 27700 nM
Compound 4: middle estimate off by 1.4-fold (0.14 log units), on the high side, within the range that was stated.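

In this assay the exchange of 3-methylthiophen-2-yl for 5-chlorothiophen-2-yl gives a 1.0-fold higher number from compound 3 to compound 4 (0.01 log units; within the scatter), so the step on this second core also stays within the scatter. The steps on the two cores cannot be told apart: the same change on two cores in this assay, a 1.5-fold higher number (0.17 log units; within the scatter) from compound 1 to compound 2 and a 1.0-fold higher number (0.01 log units; within the scatter) from compound 3 to compound 4, 1.4-fold (0.16 log units) apart, within the scatter of two such steps. This shows that the change carries from one core to the other as a step too small to read on either, but it does not show that the change has any real effect, and two cores are a narrow base for a rule about the series.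

The compounds shown leave open whether a group of another kind at this place, such as an amine or a carboxylic acid, would move the number beyond the scatter. They also leave open whether the same exchange would read alike on cores carrying neither furan nor 4-chlorophenyl groups.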